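Removing a Piperidinylmethyl Arm: What to Expect

The compounds below may be only part of what the source reports. "The series", "measured", "known", "first", "only" and "open" are said of these compounds alone.

Of the compounds shown here, two built on a shared core have been tested in a functional assay on A-431 cells (Homo sapiens) for antiproliferative activity, read by MTT assay, with a stated time of 72 h; on this read-out lower numbers stand for stronger inhibition and higher numbers for weaker inhibition. Compound 1 `O=C(Nc1ccc(CN2CCCCC2)cc1)Nc1ccc2ncnc(Nc3cccc(C(F)(F)F)c3)c2c1` gives 1550 nM, and compound 2 `O=C(Nc1cccc(CN2CCCCC2)c1)Nc1ccc2ncnc(Nc3cccc(C(F)(F)F)c3)c2c1` gives 1330 nM. Compound 2 sits alongside compound 1, the two numbers lying within the usual scatter of each other. For the measured compounds named here, compound 3 `O=C(Nc1ccccc1)Nc1ccc2ncnc(Nc3cccc(C(F)(F)F)c3)c2c1` differs from compound 2 by hydrogen in place of (piperidin-1-yl)methyl on an aromatic carbon, a change for which no measured step is known. Losing this ring-bearing arm is expected to cost a little, giving a step of a 2.0-fold higher number from compound 2 to compound 3 (0.29 log units; within the scatter) that may only just exceed the scatter. For compound 3 in this assay the estimate is 2600 nM, with a range from 800 nM to 8000 nM.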

Compound 3, half-maximal inhibitory concentration: > 10000 nM
Compound 3 ended at the assay's limit; the forecaster's own chance of this, stated with the estimate: 5%; middle value at least 3.8-fold (0.58 log units) from the limit.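

Compound 3 gives > 10000 nM in this assay, a limit of the assay and not a number. Moving the (piperidin-1-yl)methyl arm, as compound 1 and compound 2 show, left the values within the scatter, but removing it altogether matters: the loss is an at least 7.5-fold higher number from compound 2 to compound 3 (0.87 log units; beyond the scatter), and likewise an at least 6.4-fold higher number from compound 1 to compound 3 (0.80 log units; beyond the scatter). So the arm counts for much more than its placement did.

As far as these compounds go, the full size of the loss stays unknown. Also open, from the compounds shown here alone, is which part of the arm matters, and whether a bare methyl group, a dimethylaminomethyl group or a morpholine ring could take its place.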